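Shortening the chain and swapping the amine on compound 3

A few compounds are considered here, and "the series" means these few. Any claim that something is new, unique, unknown or untested is made for them only; others in the source may bear on it.

Measured compounds:
Compound 1 `CN1CCN(CCCCCn2c3c(c4ccccc42)C(=O)c2c[n+]([O-])c4ccccc4c2C3=O)CC1`: 2270 nM
Compound 2 `O=C1c2c[n+]([O-])c3ccccc3c2C(=O)c2c1c1ccccc1n2CCCCN1CCCCC1`: 610 nM
Compound 3 `O=C1c2c[n+]([O-])c3ccccc3c2C(=O)c2c1c1ccccc1n2CCN1CCCC1`: 630 nM

In a functional assay on MDA-MB-231 cells (Homo sapiens) for cytotoxicity, read by MTT assay, with a stated time of 72 h (a higher number here means a weaker inhibitor, a lower number a stronger inhibitor), compound 3 sits second highest of the three numbers; its value is within the scatter of compound 2, as a 1.0-fold higher number from compound 2 to compound 3 (0.01 log units; within the scatter) shows, while compound 1 is the clear outlier, a step of a 3.6-fold lower number from compound 1 to compound 3 (0.56 log units; beyond the scatter) away. The unmeasured compound 4 `CN1CCN(CCCCn2c3c(c4ccccc42)C(=O)c2c[n+]([O-])c4ccccc4c2C3=O)CC1` differs from compound 3 by 2-(4-methylpiperazin-1-yl)ethyl in place of pyrrolidin-1-yl on a saturated chain carbon, two bonds along the chain from an aromatic nitrogen. The two steps that bear on this change both run from compound 1: a 3.7-fold lower number from compound 1 to compound 2 (0.57 log units; beyond the scatter) and a 3.6-fold lower number from compound 1 to compound 3 (0.56 log units; beyond the scatter), each a modest drop when the 4-methylpiperazine-bearing chain gives way to a shorter chain ending in piperidin-1-yl or pyrrolidin-1-yl. Compound 4 reverses that direction, bringing the 4-methylpiperazin-1-yl group back on a chain one carbon shorter than in compound 1. Among the compounds with values here, no measured pair isolates the chain length alone, so the weight rests on those two steps. He therefore expects compound 4 to move toward compound 1, a step of roughly a 2.5-fold higher number from compound 3 to compound 4 (0.40 log units; beyond the scatter) in this assay. His estimate for compound 4 is 1600 nM, with a likely range from 700 nM to 3500 nM.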

Compound 4, half-maximal inhibitory concentration: 110 nM
Estimate against measurement, compound 4: 15-fold (1.16 log units) above; the whole stated range lies above it.
By their numbers in this assay, from the lowest: compound 4; then compounds 2 and 3 (each within the scatter of the next); then compound 1.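

In this assay the 4-methylpiperazin-1-yl group proves not to carry a high number in itself: with that amine kept and only the chain shortened, the change gives a 21-fold lower number from compound 1 to compound 4 (1.31 log units; beyond the scatter) and is the largest step among these compounds. The amine also counts on a chain of fixed length, for 4-methylpiperazin-1-yl in place of piperidin-1-yl gives a 5.5-fold lower number from compound 2 to compound 4 (0.74 log units; beyond the scatter) and so runs opposite to what compound 1 alone had suggested about this amine. Within the data shown here, the change from the shorter pyrrolidin-1-yl side chain, which alters amine and chain together, gives a 5.7-fold lower number from compound 3 to compound 4 (0.76 log units; beyond the scatter) and shows that the earlier steps had mixed two separate influences at this position. Nothing in the data accounts for these steps.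

Still open, going by these compounds, is how 4-methylpiperazin-1-yl behaves on the shorter chain of compound 3 or on a chain longer than that of compound 1, so the dependence on chain length rests on a single pair. Also open, on these data alone, is whether a morpholine or a dimethylamine at the end of the chain of compound 4 would match 4-methylpiperazin-1-yl or fall back toward piperidin-1-yl.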